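Swapping Chloro for Dimethylamino: Expected Loss of Cytotoxicity

The compounds below may be only part of what the source reports. "The series", "measured", "known", "first", "only" and "open" are said of these compounds alone.

Measured compounds:
Compound 1, `O=C1/C(=C/c2ccc(Cl)cc2)CCC/C1=C\c1ccc([N+](=O)[O-])cc1`, gives 8180 nM in a functional assay on CCRF-CEM cells (Homo sapiens) for cytotoxicity, with a stated time of 72 h; on this read-out higher numbers stand for weaker inhibition and lower numbers for stronger inhibition.
Compound 2, `CN(C)c1ccc(/C=C2\CCC/C(=C\c3ccc([N+](=O)[O-])cc3)C2=O)cc1`, reaches only a limit of this assay, > 500000 nM.
Compound 3, `O=C1/C(=C/c2ccc(Cl)cc2)CCC/C1=C\c1cccc([N+](=O)[O-])c1`, gives 1750 nM in this assay.

Compound 1 and compound 2 share one core and differ in a single place: dimethylamino in place of chloro on an aromatic carbon. This change produced an at least 61-fold higher number from compound 1 to compound 2 (1.78 log units; beyond the scatter), and the step can only be given as a bound because compound 2 sits at the limit of > 500000 nM in this assay, at which 1 of the 3 values shown sits.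

Compound 3 shares its atoms with compound 1 but they are joined differently; how the two cores differ is not broken down here. Of the two, compound 3 shows the lower number in this assay.

Compound 4, `CN(C)c1ccc(/C=C2\CCC/C(=C\c3cccc([N+](=O)[O-])c3)C2=O)cc1`, has not yet been measured. It differs from compound 3 in exactly the way compound 2 differs from compound 1: dimethylamino in place of chloro on an aromatic carbon. The place of the change is described in the same words for both pairs, so it is the same change on a related core.

Because the first pair gave an at least 61-fold higher number from compound 1 to compound 2 (1.78 log units; beyond the scatter), a comparably large weakening is expected from compound 3 to compound 4, namely a 140-fold higher number from compound 3 to compound 4 (2.15 log units; beyond the scatter). The value for compound 4 in this assay is therefore estimated at 250000 nM, with a plausible range from 40000 nM to 1000000 nM, and a real chance that only a limit is reported.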

Compound 4, half-maximal inhibitory concentration: 11700 nM
Compound 4: the middle estimate sits 21-fold (1.33 log units) above what was measured; measured number below the stated range.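

In this assay, dimethylamino in place of chloro raised the number in both pairs, so the direction of the change carried over from one core to the other, but its size did not: the same change on two cores in this assay, an at least 61-fold higher number (1.78 log units; beyond the scatter) from compound 1 to compound 2 and a 6.7-fold higher number (0.83 log units; beyond the scatter) from compound 3 to compound 4, at least 9.1-fold (0.96 log units) apart, beyond the scatter of two such steps

With dimethylamino kept in place, 3-nitrophenyl in place of 4-nitrophenyl gave an at least 42-fold lower number from compound 2 to compound 4 (1.63 log units; beyond the scatter), which shows that the loss from the swap, a 6.7-fold higher number from compound 3 to compound 4 (0.83 log units; beyond the scatter), is much smaller on the core bearing the 3-nitrophenyl group. Compound 2 gives only a limit, > 500000 nM, so the first step is a bound, and two pairs show only that the size of this step depends on the core, not how large it would be on any further core.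

From the compounds shown here alone, it remains open whether the smaller step is tied to the nitro group in this particular place or would also appear with a nitrile or a carboxylic acid there. Going by these compounds, it is equally open whether a plain amino group or a methoxy group in place of dimethylamino would cost as much on either core, and whether the two cores would still differ with those groups.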